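Urea to amide: a change without a measured precedent

The source may hold more compounds than are shown below. What is called first, only, known or untested is meant among the compounds shown, and "the series" means these compounds.

Measured so far:
compound 1 `CNC(=O)c1cc(Oc2ccc3nc(NC(=O)Nc4ccc(Cl)cc4Cl)sc3c2)ccn1`, 91.7%
compound 2 `CNC(=O)c1cc(Oc2ccc3nc(NC(=O)Nc4ccc(Br)cc4)sc3c2)ccn1`, 69.2%

Two compounds share a core and differ only in the aryl group on the urea. In a functional assay on SK-BR-3 cells (Homo sapiens) for inhibition, read by MTT assay, with a stated time of 2 days, tested at 100 uM (on this read-out higher numbers stand for more inhibition of growth at the one concentration tested and lower numbers for less inhibition of growth), compound 1 gives 91.7%, and compound 2 gives 69.2%. Compound 2 thus has the lower of the two numbers, and the step of a number 22.5 percentage points lower from compound 1 to compound 2 (beyond the scatter) lies beyond the usual scatter.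

Compound 3 `CNC(=O)c1cc(Oc2ccc3nc(NC(=O)c4ccc(Cl)cc4)sc3c2)ccn1` is not yet measured. It differs from compound 2 in a different way: 4-chlorophenyl in place of (4-bromophenyl)amino on a carbonyl carbon. The urea becomes an amide, and the halogen on the aryl ring changes as well. Within the data shown here, no measured step covers such a change; the only step known, from compound 1 to compound 2, concerns a different halogen pattern on the same kind of nitrogen-linked ring and was modest. The expectation for compound 3 therefore rests on little, and a wide range is warranted, with a step of a number 9.2 percentage points lower from compound 2 to compound 3 (within the scatter) expected to stay roughly within the scatter. Compound 3 is estimated to give 60%, ranging from 30% to 85%.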

Compound 3, percent growth inhibition at one concentration: 83%
The estimate for compound 3 lay 23 percentage points below the measured number, and the stated range covers the measured number.
By their numbers in this assay, from the lowest: compound 2; then compounds 3 and 1 (each within the scatter of the next).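

In this assay, among these compounds, the step that swaps (4-bromophenyl)amino for 4-chlorophenyl on the carbonyl carbon is a number that moves upward: a number 13.8 percentage points higher from compound 2 to compound 3 (beyond the scatter) is the first change here to reach the link itself rather than only the halogens on the ring. Measured against the other urea, the swap of (2,4-dichlorophenyl)amino for 4-chlorophenyl gives a number 8.7 percentage points lower from compound 1 to compound 3 (within the scatter) and so shows that, at this one concentration, an amide at this position can hold the level of the better urea even with the amino nitrogen and its hydrogen-bond donor gone. Nothing available explains why the numbers fall this way.

From the compounds shown here alone, both steps change the link and the ring substitution at once, so the share of each stays unknown; a (4-chlorophenyl)amino group on the same carbonyl carbon would give the urea partner that separates them from compound 3. Going by these compounds, whether the aryl ring itself is needed also stays open, as would be tested by a plain methyl or a longer chain such as butyl on that carbonyl carbon.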